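Cyclopropyl in Place of Hydrogen: an Expectation for Clearance

The source may hold more compounds than are shown below. What is called first, only, known or untested is meant among the compounds shown, and "the series" means these compounds.

Measured so far:
compound 1 `c1ccc(CNc2nnc(-c3c[nH]c4ncccc34)o2)cc1` gives 31 mL.min-1.g-1
compound 2 `Fc1cccc(CNc2nnc(-c3c[nH]c4ncccc34)o2)c1` gives 54 mL.min-1.g-1

In an ADME assay (liver) for metabolic stability, with Liver microsome (Homo sapiens) as the target, using microsomes (a higher number here means faster removal of the compound, a lower number slower removal), compound 1 stands at the lower of the two numbers, and its nearest neighbour is compound 2, with a 1.7-fold higher number from compound 1 to compound 2 (0.24 log units; within the scatter), a step that lies within the scatter. Compound 3 `c1ccc([C@H](Nc2nnc(-c3c[nH]c4ncccc34)o2)C2CC2)cc1` differs from compound 1 by cyclopropyl in place of hydrogen on a saturated chain carbon bound to an aromatic carbon and a nitrogen on an aromatic ring. Among the compounds with values here, the one measured step, a 1.7-fold higher number from compound 1 to compound 2 (0.24 log units; within the scatter), concerns a different change, fluoro in place of hydrogen on an aromatic carbon, and it does not reach beyond the scatter, so it offers no direct guide to the cyclopropyl change. Within the data shown here, with no closer precedent, compound 3 is expected to stay close to compound 1, perhaps a little higher, as a 1.5-fold higher number from compound 1 to compound 3 (0.16 log units; within the scatter). The number for compound 3 is estimated at 45 mL.min-1.g-1, with a range from 20 mL.min-1.g-1 to 100 mL.min-1.g-1.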

Compound 3, intrinsic clearance in microsomes: 56 mL.min-1.g-1
For compound 3 the middle estimate is 1.2-fold (0.09 log units) below the measured one; the measured number falls inside the stated range.
By their numbers in this assay, from the lowest: compounds 1, 2 and 3 (each within the scatter of the next).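

In this assay, the saturated chain carbon bound to an aromatic carbon and a nitrogen on an aromatic ring carries cyclopropyl with a step of a 1.8-fold higher number from compound 1 to compound 3 (0.26 log units; within the scatter). Compounds 1 and 2 differ only on an aromatic carbon, so they said nothing about this chain carbon; compound 3 shows that adding this three-membered carbon ring here gives no step beyond the scatter. Nothing available explains this outcome or links it to any property of the group. From the compounds shown here alone, whether a methyl, a longer chain or an amine on the same carbon would also stay within the scatter remains open. Also open, going by these compounds, is how fluoro on the aromatic carbon and cyclopropyl on the chain carbon would behave together in one compound in this assay.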